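Sulfonamide series: expectation for compound 4 from compound 1

The source may report more compounds than this note shows. Statements on the series, on what has been measured and on what is new or still open speak of the compounds shown alone.

Measured so far in a functional assay on HT-29 cells (Homo sapiens) for antiproliferative activity, read by sulforhodamine B assay, with a stated time of 48 h; on this read-out higher numbers stand for weaker inhibition and lower numbers for stronger inhibition:
- compound 1 `CCc1ccccc1NS(=O)(=O)c1ccc(N2CCNC2=O)cc1` gives 240 nM
- compound 2 `O=C1NCCN1c1ccc(S(=O)(=O)Nc2ccc(I)cc2)cc1` gives 650 nM
- compound 3 `O=C1NCCN1c1ccc(S(=O)(=O)Nc2ccc(Br)cc2)cc1` gives 300 nM

Compound 1 stands lowest of the three numbers in this assay; compound 3 is nearest, a 1.3-fold higher number from compound 1 to compound 3 (0.10 log units; within the scatter), and compound 2 furthest, a 2.7-fold higher number from compound 1 to compound 2 (0.43 log units; beyond the scatter). Compound 4 `O=C1NCCN1c1ccc(S(=O)(=O)Nc2cccc(Cl)c2)cc1` differs from compound 1 in one place: 3-chlorophenyl in place of 2-ethylphenyl on a sulfonamide nitrogen. Going by the values given here, the steps that bear on this are the two earlier exchanges of 2-ethylphenyl for a halophenyl, a 1.3-fold higher number from compound 1 to compound 3 (0.10 log units; within the scatter) and a 2.7-fold higher number from compound 1 to compound 2 (0.43 log units; beyond the scatter), plus the halogen swap a 2.2-fold lower number from compound 2 to compound 3 (0.34 log units; beyond the scatter). Among the compounds with values here, no measured compound carries a chloro group or a 3-substituted phenyl, so the expected step in this assay is modest at most, toward a somewhat higher number. Compound 4 is estimated at 350 nM (range 150 nM to 850 nM), an expected step of a 1.5-fold higher number from compound 1 to compound 4 (0.16 log units; within the scatter).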

Compound 4, half-maximal inhibitory concentration: 55 nM
Estimate against measurement, compound 4: 6.4-fold (0.80 log units) above; the measured number lies below the stated range.
By their numbers in this assay, from the lowest: compound 4; then compounds 1 and 3 (each within the scatter of the next); then compound 2.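

In this assay, the aryl group on the sulfonamide nitrogen can lower the number well beyond the scatter: 3-chlorophenyl gives a 4.4-fold lower number from compound 1 to compound 4 (0.64 log units; beyond the scatter), a 5.5-fold lower number from compound 3 to compound 4 (0.74 log units; beyond the scatter) and a 12-fold lower number from compound 2 to compound 4 (1.07 log units; beyond the scatter). Before this, no replacement of 2-ethylphenyl had given a lower number than compound 1. Nothing available accounts for this step.

The compounds shown leave open whether the lower number follows the chloro group or its place on the phenyl ring, as 4-chlorophenyl or 3-bromophenyl would tell. From the compounds shown here alone, how an amine or a carboxylic acid on that phenyl ring would read also remains open.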